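Two Limits and an Unmeasured Chlorophenyl Compound

The source may report more compounds than this note shows. Statements on the series, on what has been measured and on what is new or still open speak of the compounds shown alone.

Compound 1 `CC(C)N(Cc1cccc(OCCCCCC(=O)O)c1)C(=O)c1ccc(-c2cccc(Cl)c2)cc1`: > 21900 nM (a limit)
Compound 2 `CCOC(=O)CCCCCOc1cccc(CN(C(=O)c2ccc(-c3cc(F)cc(OC)c3)cc2)C(C)C)c1`: > 26000 nM (a limit)

In an ADME assay on HEK293 cells (Homo sapiens) for cytotoxicity, read by CellTiter-Glo and resazurin assay, with a stated time of 72 h (a lower number here means that less compound is needed, a higher number that more compound is needed for the effect), compound 2 gives > 26000 nM, which is a limit and not a number. Compound 1 is also known only by a limit, so the two compounds cannot be ranked. Compound 3 `CCOC(=O)CCCCCOc1cccc(CN(C(=O)c2ccc(-c3cccc(Cl)c3)cc2)C(C)C)c1` has not yet been measured. It differs from compound 2 by one change: 3-chlorophenyl in place of 3-fluoro-5-methoxyphenyl on an aromatic carbon. Among the compounds with values here, no measured step exists as a guide, so no change beyond the scatter is expected in this assay. The expected step is small, an at least 1.0-fold lower number from compound 2 to compound 3 (0.01 log units; that floor lies within the scatter). For compound 3 the estimated value is 25000 nM, with an expected range of 12000 nM to 50000 nM.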

Compound 3, half-maximal effective concentration: > 18400 nM
Compound 3: no number, only a limit; the forecaster's own chance of this, stated with the estimate: 85%; the middle value is on the limit's open side.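

Compound 3, like compound 1 and compound 2, is known only as a limit in this assay, and the steps from compound 2 and from compound 1 to compound 3 cannot be read. On these data alone, whether 3-chlorophenyl or ethyl changes the concentration needed for cytotoxicity remains open.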